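Swapping the benzyl ether of compound 1 for an isobutyl chain

This account rests on a few compounds, and the source may have more. Where it says the series, first, only, none or still open, it means among the compounds named here.

Of the compounds shown here, three sharing one core have been measured in an assay on CHO-K1 cells for displacement of a labelled ligand from prostaglandin E2 receptor EP1 subtype (Homo sapiens); on this read-out lower numbers stand for stronger inhibition and higher numbers for weaker inhibition. Compound 1 `Cc1cc(C(N)=O)nn1Cc1cc(Cl)ccc1OCc1ccccc1` gives 126 nM in this assay. Compound 2 `Cc1cc(C(=O)Nc2ccc(F)cc2)nn1Cc1cc(Cl)ccc1OCc1ccccc1` gives 79.4 nM, and compound 3 `Cc1cc(C(=O)NCc2ccccn2)nn1Cc1cc(Cl)ccc1OCc1ccccc1` gives 25.1 nM. On these numbers compound 1 stands highest: the step of a 1.6-fold lower number from compound 1 to compound 2 (0.20 log units; within the scatter) is within the scatter, whereas the step of a 5.0-fold lower number from compound 1 to compound 3 (0.70 log units; beyond the scatter) is beyond it, as is the step of a 3.2-fold lower number from compound 2 to compound 3 (0.50 log units; beyond the scatter).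

Compound 4 `Cc1cc(C(N)=O)nn1Cc1cc(Cl)ccc1OCC(C)C` differs from compound 1 at another place entirely: isopropyl in place of phenyl on a saturated chain carbon bound to an oxygen on an aromatic ring. The three measured steps all change what sits on the amide-type nitrogen, and none of them touches the chain on the oxygen of the aromatic ring. Nothing measured here therefore bears directly on the change from compound 1 to compound 4, and the direction of the step cannot be read from the data. A step of uncertain size, with a wide range, is the most honest expectation for this assay.

For compound 4 the estimated value in this assay is 250 nM, with a range from 60 nM to 1000 nM. This estimate means an expected step of a 2.0-fold higher number from compound 1 to compound 4 (0.30 log units; within the scatter).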

Compound 4, half-maximal inhibitory concentration: 126 nM
Beside the measured number, compound 4's estimate is 2.0-fold (0.30 log units) above it; measured number inside the range.
By their numbers in this assay, from the lowest: compound 3; then compounds 2, 1 and 4 (each within the scatter of the next).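

In this assay, among the compounds shown here, this is the first look at the chain on the oxygen of the aromatic ring, and putting isopropyl in place of phenyl at this place gives no change at the digits printed from compound 1 to compound 4 (within the scatter). With the amide nitrogen left carrying only hydrogens, a six-membered aromatic ring is therefore not required here to keep the read-out within the scatter, as isopropyl, with 3 heavy atoms and no ring, serves as well as phenyl, with 6 heavy atoms. Nothing available explains why these two groups read alike.

The compounds shown leave open whether the same swap would read alike with the (pyridin-2-yl)methyl group of compound 3 on the amide nitrogen, since the isobutyl chain appears here only on the unsubstituted amide. They also leave open how far this place can be varied, for example with a bare methyl, a longer chain such as n-hexyl, or a chain ending in an amine or a carboxylic acid.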